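From Heptyl to Tert-Butoxy on a Carbonyl Carbon

The source may hold more compounds than are shown below. What is called first, only, known or untested is meant among the compounds shown, and "the series" means these compounds.

Of the compounds shown here, three have been measured in a functional assay on HT-29 cells (Homo sapiens) for antiproliferative activity, read by sulforhodamine B assay, with a stated time of 72 h (a lower number here means a stronger inhibitor, a higher number a weaker inhibitor), and their numbers lie within the usual scatter of one another. Compound 1 (`CCCCCCCCc1ccc(CCC(CO)(CO)NC(=O)CCCCCCC)c2ccccc12`) gives 22000 nM while compound 2 (`CCCCCCCOc1ccc(CCC(CO)(CO)NC(=O)CCCCC)c2ccccc12`) gives 21900 nM and compound 3 (`CCCCCCCOc1ccc(CCC(CO)(CO)NC(=O)CCCCCCC)c2ccccc12`) gives 18800 nM with no real separation among them. Compound 3 therefore stands level with both of the others.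

The next structure, compound 4 (`CCCCCCCOc1ccc(CCC(CO)(CO)NC(=O)OC(C)(C)C)c2ccccc12`), carries tert-butoxy in place of heptyl on a carbonyl carbon and is otherwise the same as compound 3.

Two measured steps offer some guidance. On an aromatic carbon the series shows a 1.2-fold lower number from compound 1 to compound 3 (0.07 log units; within the scatter) and this change lies away from the new group. On a saturated chain carbon, five bonds along the chain from a carbonyl carbon, it shows a 1.2-fold lower number from compound 2 to compound 3 (0.07 log units; within the scatter) and this is the closer precedent. Neither step tests tert-butoxy, so the evidence for this change is thin. Both steps are small, so no move beyond the scatter is expected, though the uncertainty remains wide. The estimated step is a 1.2-fold higher number from compound 3 to compound 4 (0.07 log units; within the scatter) in this assay on this reasoning. Compound 4 is expected at 22000 nM with 11000 nM to 45000 nM as its estimated range.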

Compound 4, half-maximal inhibitory concentration: 21400 nM
Compound 4: the middle estimate sits 1.0-fold (0.01 log units) above what was measured; the range from low to high includes it.
By their numbers in this assay, from the lowest: compounds 3, 4, 2 and 1 (each within the scatter of the next).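

In this assay, tert-butoxy on the carbonyl carbon gives a 1.1-fold higher number from compound 3 to compound 4 (0.06 log units; within the scatter) when it replaces heptyl, and a 1.0-fold lower number from compound 2 to compound 4 (0.01 log units; within the scatter) when it replaces pentyl. The earlier compounds shown here carried only heptyl or pentyl at this place, whereas compound 4 turns the (heptylcarbonyl)amino group into a (tert-butoxycarbonyl)amino group, and this different kind of group, with an oxygen on the carbonyl carbon and a branched end, still leaves the number within the scatter of both chains. Nothing available explains why the number holds across this exchange.

Since every step at this carbonyl carbon so far lies within the scatter, the compounds shown do not reveal whether any group here can separate one compound from another in this assay. From the compounds shown here alone, it remains open whether a free amine at this place, a carboxylic acid at the end of the chain, a ring such as phenyl on the carbonyl carbon, or a much longer chain would give a number outside that scatter.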